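The source may report more compounds than this note shows. Statements on the series, on what has been measured and on what is new or still open speak of the compounds shown alone.

In this series of pyridyl ethers tested in an assay on membranes from brain for displacement of a labelled ligand from Neuronal acetylcholine receptor; alpha4/beta2 (Rattus norvegicus) (a higher number here means a weaker inhibitor, a lower number a stronger inhibitor), compound 1 `Cc1ncccc1OC[C@@H]1CCCN1C` gives 22.9 nM. Compound 2 `CN1CCC[C@H]1COc1cccnc1Br` carries bromo in place of methyl on an aromatic carbon and in this assay compound 2 gives 451 nM; the step of a 20-fold higher number from compound 1 to compound 2 (1.29 log units; beyond the scatter) is large. Compound 3 `Cc1ccncc1OC[C@@H]1CCCN1C` has the same atoms as compound 1 joined differently; the difference between the two cores is not broken down here. In this assay compound 3 gives 4.12 nM, the lowest of the three numbers, while compound 2 stands farthest from it.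

Compound 4 `CN1CCC[C@H]1COc1cnccc1Br` is not yet measured. Relative to compound 3 it carries bromo in place of methyl on an aromatic carbon. This is the same kind of change as that from compound 1 to compound 2, not the same: there the bromo sits next to the ring nitrogen, here it sits opposite the ring nitrogen, in both cases ortho to a group of 8 heavy atoms.

Because a 20-fold higher number from compound 1 to compound 2 (1.29 log units; beyond the scatter) was measured, compound 4 is expected to show a step of a 12-fold higher number from compound 3 to compound 4 (1.08 log units; beyond the scatter), a weakening of comparable kind, tempered somewhat for the different place. For compound 4 the expected value in this assay is 50 nM, with a likely range from 15 nM to 200 nM.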

Compound 4, inhibition constant: 28 nM
Compound 4: middle estimate off by 1.8-fold (0.25 log units), on the high side; measured number inside the range.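

In this assay, bromo in place of methyl on an aromatic carbon again gives a weaker inhibitor, with a 6.8-fold higher number from compound 3 to compound 4 (0.83 log units; beyond the scatter). The direction of the change therefore holds on both cores, but its size does not carry over unchanged: the same change on two cores in this assay, a 20-fold higher number (1.29 log units; beyond the scatter) from compound 1 to compound 2 and a 6.8-fold higher number (0.83 log units; beyond the scatter) from compound 3 to compound 4, 2.9-fold (0.46 log units) apart, beyond the scatter of two such steps

For the compounds shown here, this gives a direction that can reasonably be expected across these two cores, while a size measured on one core is not a reliable figure for the other; with only two pairs, the data do not explain why the steps differ or show which size, if either, a further core would follow.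

The compounds shown leave open how other groups on this aromatic carbon would compare with methyl and bromo, such as chloro, methoxy or a nitrile. They also leave open whether the weakening seen with bromo would hold against a plain hydrogen at the same place.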